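Quinolinyloxy in place of triazolylsulfanyl on the ketone chain

The source may report more compounds than this note shows. Statements on the series, on what has been measured and on what is new or still open speak of the compounds shown alone.

Compound 1, `CC(C)[C@H](NC(=O)COc1cccc2ccccc12)C(=O)N[C@@H](CC(=O)O)C(=O)CSc1nncn1C`, in a functional assay on Jurkat cells (Homo sapiens) for inhibition (a lower number here means a stronger inhibitor, a higher number a weaker inhibitor), gives only a limit, > 200000 nM. Compound 2, `CC(C)[C@H](NC(=O)COc1cccc2ccccc12)C(=O)N[C@@H](CC(=O)O)C(=O)COc1cc(C(F)(F)F)ncn1`, gives in this assay likewise only a limit, > 200000 nM. On the numbers shown, compound 1 stands therefore at a limit, and the one further value shown is a limit as well. Going by the values given here, the single measured step, a step that the two limits leave unreadable from compound 1 to compound 2, has no readable size because of the limit of > 200000 nM in this assay, at which 2 of the 2 values shown sit.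

Compound 3, `CC(C)[C@H](NC(=O)COc1cccc2ccccc12)C(=O)N[C@@H](CC(=O)O)C(=O)COc1cccc2cccnc12`, is the next member; the change from compound 1 to compound 3 is (quinolin-8-yl)oxy in place of (4-methyl-4H-1,2,4-triazol-3-yl)sulfanyl on a saturated chain carbon bound to a carbonyl carbon. The group that enters, (quinolin-8-yl)oxy, brings two fused six-membered aromatic rings where the five-membered ring of (4-methyl-4H-1,2,4-triazol-3-yl)sulfanyl stood, at the same place on the saturated chain carbon bound to a carbonyl carbon.

Among the compounds with values here, no measured step bears on this change with a readable size, since both values in this assay sit at the limit. The step is therefore expected to read about a number no higher from compound 1 to compound 3 (the limit leaves the size open), with wide uncertainty. Compound 3 is estimated at 200000 nM, in a range from 20000 nM to 400000 nM, most likely again reported only as a limit.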

Compound 3, half-maximal inhibitory concentration: > 200000 nM
Compound 3 gave a limit, no number; the forecaster's own chance of this, stated with the estimate: 60%; the middle value sits exactly at the limit.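

No step can be read among compound 1, compound 2 and compound 3, since each gives only a limit and no number: the limit of > 200000 nM in this assay, at which 3 of the 3 values shown sit.

The compounds shown leave open how strongly any of the three inhibits in this assay, and whether the group on the saturated chain carbon bound to a carbonyl carbon alters inhibition at all.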